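The source may report more compounds than this note shows. Statements on the series, on what has been measured and on what is new or still open speak of the compounds shown alone.

Working notes on the series.

Three compounds have numbers in a functional assay on MCF7 cells (Homo sapiens) for inhibition, read by MTT assay, with a stated time of 72 h; a lower number here means a stronger inhibitor, a higher number a weaker inhibitor. Compound 1, `CCCCCc1c(C)nc2nc(SCc3ccc(Cl)cc3)nn2c1Nc1cc(-c2ccccc2)[nH]n1`, gives 6390 nM in this assay. Compound 3, `Cc1ccc(Cn2ccc(Nc3cc(C)nc4nc(SCc5ccc(Br)cc5)nn34)n2)cc1`, gives 11300 nM in this assay. Compound 2, `Cc1cc(Nc2cc(-c3ccccc3)[nH]n2)n2nc(SCc3nc4ccccc4[nH]3)nc2n1`, gives 2730 nM in this assay, the lowest of the three numbers; its gap to compound 1 and its gap to compound 3 both lie beyond the scatter, so compound 2 stands as the strongest inhibitor of the measured set. Among the compounds with values here, no pair among the three differs in only one place, so no single-change step is available as a guide.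

Compound 4, `Cc1cc(Nc2cc(-c3ccccc3)[nH]n2)n2nc(SCC3CCCCC3)nc2n1`, is not yet measured. It differs from compound 2 in one place: cyclohexyl in place of 1H-benzimidazol-2-yl on a saturated chain carbon bound to a sulfur. The group that leaves carries one hydrogen-bond donor and one hydrogen-bond acceptor; the cyclohexyl that enters carries none. Among the measured compounds, the sulfur-linked arm is either a benzimidazolylmethyl (compound 2) or a halobenzyl (compounds 1 and 3), and the benzyl cases give higher numbers, though other parts of those molecules also differ.

The step from compound 2 to compound 4 is expected to be a modest rise in the number, somewhat beyond the scatter, a 2.2-fold higher number from compound 2 to compound 4 (0.34 log units; beyond the scatter). Compound 4 is estimated at 6000 nM in this assay, within 2500 nM to 15000 nM.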

Compound 4, half-maximal inhibitory concentration: > 50000 nM
Compound 4 gave a limit, no number; the forecaster's own chance of this, stated with the estimate: 5%; middle value at least 8.3-fold (0.92 log units) away from the limit.
By their numbers in this assay, from the lowest: compound 2; then compounds 1 and 3 (each within the scatter of the next). At a limit, above all of these: compound 4.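

The arm on the saturated chain carbon bound to a sulfur proves to be a sensitive place: cyclohexyl in place of 1H-benzimidazol-2-yl gives an at least 18-fold higher number from compound 2 to compound 4 (1.26 log units; beyond the scatter). Within the data shown here, this is the first single-change step, and the earlier compounds, which differ from one another in more than one place, could not isolate this arm's contribution. The size of the step is only a bound, as compound 4 gives no number in this assay but a limit: the limit of > 50000 nM in this assay, at which 1 of the 4 values shown sits.

The compounds shown leave open which difference matters, as the aromatic rings, the hydrogen-bond donor and the hydrogen-bond acceptor all leave in the same change. A phenyl, a pyridin-2-yl or an imidazol-2-yl on that same chain carbon would begin to separate these features.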